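A few compounds are considered here, and "the series" means these few. Any claim that something is new, unique, unknown or untested is made for them only; others in the source may bear on it.

Measured compounds: compound 1, `CC(c1ccc(-c2ccccc2)c(F)c1)c1n[nH]c(=S)n1N`, with "not active" (no number reported) in a functional assay on SNU-475 cells (Homo sapiens) for inhibition, read by sulforhodamine B assay, with a stated time of 72 h; a higher number here means a weaker inhibitor, a lower number a stronger inhibitor. Compound 2, `COc1ccc(C2=Nn3c(nnc3C(C)c3ccc(-c4ccccc4)c(F)c3)SC2)cc1`, with 6700 nM in this assay.

Within the data shown here, compound 1 gave no number in this assay, so compound 2 holds the only measured value. Compound 3, `CC(c1ccc(-c2ccccc2)c(F)c1)c1nnc2n1N=C(c1ccc(F)cc1)CS2`, differs from compound 2 by one change: fluoro in place of methoxy on an aromatic carbon. Among the measured compounds shown here, no measured step of this kind is available here, so the size of the expected step rests on the single value of compound 2 and on the smallness of the change. A step within the usual scatter, with little tendency toward weaker inhibition, seems most plausible. Compound 3 is therefore expected at 8500 nM, estimated between 3000 nM and 25000 nM, which means an expected step of a 1.3-fold higher number from compound 2 to compound 3 (0.10 log units; within the scatter).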

Compound 3, half-maximal inhibitory concentration: 6600 nM
Estimate against measurement, compound 3: 1.3-fold (0.11 log units) above, within the range that was stated.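

The exchange of 4-methoxyphenyl for 4-fluorophenyl gives a 1.0-fold lower number from compound 2 to compound 3 (0.01 log units; within the scatter) in this assay and thus shows that this place, on an aromatic carbon para to a large group, accepts either group with values that cannot be told apart. Among these compounds, this is the first step that can be read between two numbers, as compound 1 gave none.

As far as these compounds go, whether an amine or a carboxylic acid at this place would read the same stays open. No outside evidence bears on this result.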